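This account rests on a few compounds, and the source may have more. Where it says the series, first, only, none or still open, it means among the compounds named here.

Measured so far:
compound 1 `O=C(N/N=C/c1ccccc1F)c1cnccn1` — 81%
compound 2 `O=C(N/N=C/c1ccc(Br)cc1)c1cnccn1` — 94%

In an ADME assay on J774 cells (Mus musculus) for cytotoxicity, read by MTT assay, with a stated time of 48 h, tested at 150 ug/mL (on this read-out higher numbers stand for a weaker effect at the one concentration tested and lower numbers for a stronger effect), compound 1 gives 81%, while compound 2 gives 94%. Of these two numbers compound 1 has the lower one, and its gap to compound 2 lies beyond the usual scatter, so compound 1 shows the stronger effect of the pair. Both compounds share the same core and differ only in the substituent on the six-membered aromatic ring of carbon only.

Compound 3 `N#Cc1ccccc1/C=N/NC(=O)c1cnccn1` has not yet been measured. Compared with compound 1 it carries cyano in place of fluoro on an aromatic carbon. Within the data shown here, no measured pair shows what such a change does here, so the size of the step in this assay is open; a small step is expected, in either direction, most likely not beyond the scatter. Compound 3 is estimated at 85%, within a range from 70% to 98%. That estimate means an expected step of a number 4 percentage points higher from compound 1 to compound 3 (within the scatter).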

Compound 3, a percentage reported as activity, at one concentration (the size of the read-out at that concentration, not a potency): 70%
Beside the measured number, compound 3's estimate is 15 percentage points above it; low and high end bracket the measured number.
By their numbers in this assay, from the lowest: compound 3; then compound 1; then compound 2.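

In this assay, putting cyano in place of fluoro on an aromatic carbon, ortho to a large group, gives a number 11 percentage points lower from compound 1 to compound 3 (beyond the scatter) and so a stronger effect at the one concentration tested. Among these compounds, this is the only pair so far that differs in one place, and it shows that the read-out responds to the group at this position, with the change from fluoro to cyano moving it past the usual scatter. No supporting measurement bears on why this step occurs.

A single step cannot show whether the same trend would hold for other groups at this position, such as an amine or a carboxylic acid. It also leaves open whether cyano would have a similar effect on a different aromatic carbon of the same ring.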